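The source may hold more compounds than are shown below. What is called first, only, known or untested is meant among the compounds shown, and "the series" means these compounds.

This account follows the step from compound 1 to compound 4 in a functional assay for inhibition, with Oryctolagus cuniculus as the target; a higher number here means a weaker inhibitor, a lower number a stronger inhibitor. Compound 1, `CN(C(=O)C[C@@H](N)CCCN=C(N)N)C1CN=C(NC(N)=O)NC1=O`, gives 170 nM in this assay. Compound 2, `CN(C(=O)C[C@@H](N)CCCCN)C1CN=C(NC(N)=O)NC1=O`, gives 2800 nM, and compound 3, `CN(C(=O)C[C@@H](N)CCCCN)C1CN=C(Nc2ccccn2)NC1=O`, gives 200 nM. Among these three numbers compound 1 stands lowest; compound 3 lies nearest to it, within the scatter, and compound 2 lies furthest, beyond the scatter.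

Compound 4 is `CN(C(=O)C[C@@H](N)CCCN=C(N)N)C1CN=C(Nc2ccc3ccccc3n2)NC1=O`. It differs from compound 1 by quinolin-2-yl in place of carbamoyl on an amine nitrogen. Of the measured steps, the one that bears on this change is a 14-fold lower number from compound 2 to compound 3 (1.15 log units; beyond the scatter), where pyridin-2-yl took the place of carbamoyl on the same amine nitrogen. The other step, a 16-fold higher number from compound 1 to compound 2 (1.22 log units; beyond the scatter), alters a different part of the structure and gives no guidance here. Quinolin-2-yl is not pyridin-2-yl, so the size of the step is uncertain, but the direction of the measured replacement suggests that a lower number is to be expected for compound 4, and a step of a 5.7-fold lower number from compound 1 to compound 4 (0.75 log units; beyond the scatter) in this assay is estimated. Compound 4 is therefore expected to give about 30 nM in this assay, with a range from 8 nM to 120 nM.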

Compound 4, half-maximal inhibitory concentration: 100 nM
The estimate for compound 4 lay 3.3-fold (0.52 log units) below the measured number; measured number inside the range.
By their numbers in this assay, from the lowest: compounds 4, 1 and 3 (each within the scatter of the next); then compound 2.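

On this amine nitrogen, with the chain of compound 1 in place, quinolin-2-yl stands in for carbamoyl in this assay with a 1.7-fold lower number from compound 1 to compound 4 (0.23 log units; within the scatter), so a group of two fused aromatic rings is accommodated here with no change beyond the scatter. The earlier step at the same nitrogen, made on the shorter amine-ended chain, was of a different size, at a 14-fold lower number from compound 2 to compound 3 (1.15 log units; beyond the scatter), which shows that replacing carbamoyl with an aromatic ring does not give a large step in every case; compounds 2 and 3 and compounds 1 and 4 differ in both the chain and the entering group, so these two steps alone cannot say which of the two sets the size. No measurement shown here explains why the two steps differ in size.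

The compounds shown leave open how pyridin-2-yl would read on the chain of compound 1, and how quinolin-2-yl would read on the chain of compound 2, which would separate the chain from the ring. They also leave open how a phenyl or a methyl on this amine nitrogen would compare with carbamoyl and quinolin-2-yl.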